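The compounds below may be only part of what the source reports. "The series", "measured", "known", "first", "only" and "open" are said of these compounds alone.

The measured compounds:
Compound 1 `COc1ccc(-c2cc(/C=C/C(=O)c3ccc(OC)c(OC)c3)[nH]n2)cc1`: 61%
Compound 2 `COc1cc(-c2cc(/C=C/C(=O)c3ccc(Cl)c(Cl)c3)[nH]n2)cc(OC)c1OC`: 81%
Compound 3 `COc1ccc(-c2cc(/C=C/C(=O)c3ccc(N)cc3)[nH]n2)cc1`: 61%

In a functional assay on UO-31 cells (Homo sapiens) for cytotoxicity, read by sulforhodamine B assay, with a stated time of 48 h, tested at 1 uM (on this read-out lower numbers stand for a stronger effect and higher numbers for a weaker effect at the one concentration tested), compound 2 gives the highest number of the three, and its value 81% lies beyond the scatter above both compound 1 and compound 3, so it shows the weakest effect among them. Compound 4 `COc1ccc(C(=O)/C=C/c2cc(-c3cc(OC)c(OC)c(OC)c3)n[nH]2)cc1OC` differs from compound 2 in one place: 3,4-dimethoxyphenyl in place of 3,4-dichlorophenyl on a carbonyl carbon. Compound 1, which already carries a 3,4-dimethoxyphenyl on a carbonyl carbon, gives 61% in this assay, a lower number. Among the measured compounds shown here, no measured pair shows this exact change, so the size of the step is uncertain; a fall in the number seems plausible, but it may stay within the scatter. Compound 4 is therefore expected to give 68%, between 50% and 88%. The expected step of a number 13 percentage points lower from compound 2 to compound 4 (beyond the scatter) points toward a somewhat stronger effect.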

Compound 4, a percentage reported as activity, at one concentration (the size of the read-out at that concentration, not a potency): 67%
Compound 4: the middle estimate sits 1 percentage points above what was measured; the range from low to high includes it.
By their numbers in this assay, from the lowest: compounds 1, 3 and 4 (each within the scatter of the next); then compound 2.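

In this assay, putting 3,4-dimethoxyphenyl in place of 3,4-dichlorophenyl on a carbonyl carbon gives a number 14 percentage points lower from compound 2 to compound 4 (beyond the scatter). Among the compounds shown here, this is the first single-place comparison in the set, and it shows that the group at this position can change the read-out, with the dimethoxy compound having the stronger effect of the pair at this one concentration. Nothing available explains the shift.

On these data alone, whether a carboxylic acid or a trifluoromethyl group on this ring would shift the number further remains open. So does whether the same swap has a similar effect when the rest of the molecule differs.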